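Swapping 3,4-difluorophenyl for pyridin-4-yl on the shared core

A few compounds are considered here, and "the series" means these few. Any claim that something is new, unique, unknown or untested is made for them only; others in the source may bear on it.

compound 1 `COc1ccc(S(=O)(=O)N2CCc3cccc(-c4ccc(N)cc4)c32)cc1`: 162 nM
compound 2 `COc1ccc(S(=O)(=O)N2CCc3cccc(-c4ccc(F)c(F)c4)c32)cc1`: 55.5 nM

Among the compounds with values here, in a functional assay on MKN-45 cells (Homo sapiens) for inhibition, with a stated time of 72 h (a higher number here means a weaker inhibitor, a lower number a stronger inhibitor), compound 2 holds the lower of the two numbers so far, at 55.5 nM. Within the data shown here, the next compound, compound 3 `COc1ccc(S(=O)(=O)N2CCc3cccc(-c4ccncc4)c32)cc1`, keeps the shared core and alters only one group: pyridin-4-yl in place of 3,4-difluorophenyl on an aromatic carbon. Pyridin-4-yl stands in place of 3,4-difluorophenyl on an aromatic carbon. Among the measured compounds shown here, one measured step bears on this place: a 2.9-fold lower number from compound 1 to compound 2 (0.47 log units; beyond the scatter), a modest change beyond the scatter. Neither measured compound carries an aromatic ring with a hetero atom at this place, so the data give no firm direction. A step of no more than similar modest size is therefore expected, with only a slight lean towards a lower number. The expected step is a 1.2-fold lower number from compound 2 to compound 3 (0.09 log units; within the scatter). In this assay, compound 3 is expected at 45 nM, within an estimated range from 12 nM to 170 nM.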

Compound 3, half-maximal inhibitory concentration: 69.5 nM
Compound 3: middle estimate off by 1.5-fold (0.19 log units), on the low side, within the range that was stated.
By their numbers in this assay, from the lowest: compounds 2 and 3 (each within the scatter of the next); then compound 1.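

In this assay, the aromatic carbon of the shared core takes a ring with a hetero atom as well as a ring of carbon only: pyridin-4-yl in place of 3,4-difluorophenyl gives a 1.3-fold higher number from compound 2 to compound 3 (0.10 log units; within the scatter), a step within the scatter. The same group set against 4-aminophenyl gives a 2.3-fold lower number from compound 1 to compound 3 (0.37 log units; beyond the scatter), so among these three compounds the lower numbers do not depend on fluorine, and compound 1 alone stands apart. No measurement given here explains why these groups compare as they do.

The compounds shown leave open whether the place of the ring nitrogen matters, as pyridin-3-yl would show, and whether an aromatic ring is needed here at all, as morpholine would show. They also leave open whether the higher number of compound 1 belongs to its free amine, which an acetamide would help to show.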